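This account rests on a few compounds, and the source may have more. Where it says the series, first, only, none or still open, it means among the compounds named here.

In a functional assay on isolated protein for inhibition of Glucose-dependent insulinotropic receptor (Rattus norvegicus), read by HTRF and cAMP accumulation (on this read-out lower numbers stand for smaller maximal responses and higher numbers for larger maximal responses), two compounds have been measured so far. Compound 1 `Cc1nc(S(C)(=O)=O)ccc1Oc1ncnc(OC2CCN(C(=O)O[C@H](C)C(F)(F)F)CC2)c1F` gives 85% in this assay. For the measured compounds named here, compound 2 `CCC(F)(F)C(=O)N1CCC(Oc2ncnc(Oc3ccc(S(C)(=O)=O)nc3C)c2F)CC1` gives 90% in this assay, and the only measured step, a number 5 percentage points higher from compound 1 to compound 2 (within the scatter), stays within the scatter, so the two numbers cannot be told apart with confidence. Compound 3 `Cc1nc(S(C)(=O)=O)ccc1Oc1ncnc(OC2CCN(C(=O)c3noc(C(C)(C)F)n3)CC2)c1F` has not yet been measured. It differs from compound 2 in one place: a group of 9 heavy atoms (5 carbon, 2 nitrogen, 1 oxygen, 1 fluorine; one five-membered aromatic ring with 3 hetero atoms) in place of a group of 5 heavy atoms (3 carbon, 2 fluorine; no ring), on a carbonyl carbon. Going by the values given here, the one step that bears on this change is a number 5 percentage points higher from compound 1 to compound 2 (within the scatter), which also swapped the group on the same carbonyl carbon and produced no movement beyond the scatter. On that basis the expectation for this assay is a step of a number 2 percentage points lower from compound 2 to compound 3 (within the scatter), that is, no change beyond the scatter. Compound 3 is therefore estimated to reach 88% in this assay, with a range from 72% to 100%.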

Compound 3, largest response reached (reported as efficacy), in percent of the reference or control that the assay uses: 74%
For compound 3 the middle estimate is 14 percentage points above the measured one; low and high end bracket the measured number.
By their numbers in this assay, from the lowest: compound 3; then compounds 1 and 2 (each within the scatter of the next).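

The group on the carbonyl carbon whose other neighbour is the amide-type nitrogen in a ring can matter in this assay: the group with a five-membered aromatic ring brings a number 16 percentage points lower from compound 2 to compound 3 (beyond the scatter), where the earlier swap at this place had moved nothing beyond the scatter. The comparison with the other open-chain group points the same way, with a number 11 percentage points lower from compound 1 to compound 3 (beyond the scatter), so the two open-chain groups sit together and the ring-bearing group sits apart from both. No measurement here accounts for this difference.

The compounds shown leave open whether the lower response belongs to the five-membered aromatic ring itself or to the rest of the entering group. A plain methyl group on that ring in place of the fluorine-bearing part, or a phenyl ring on the same carbonyl carbon, would help to separate the two.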